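The source may report more compounds than this note shows. Statements on the series, on what has been measured and on what is new or still open speak of the compounds shown alone.

Measured compounds:
- Compound 1, `COC1=C(C)C(=O)/C(=C(O)/C=C/c2cccc(OC)c2)C(=O)C1(C)C`: 2.9 ug/mL
- Compound 2, `COC1=C(C)C(=O)/C(=C(O)/C=C/c2ccc(F)cc2)C(=O)C1(C)C`: "not determined" (no result reported)
- Compound 3, `COC1=C(C)C(=O)/C(=C(O)/C=C/c2c(C)cccc2C)C(=O)C1(C)C`: "not determined" (no result reported)

Compound 1 is the only one of these three with a number in a functional assay on 1A9 cells (Homo sapiens) for cytotoxicity; on this read-out higher numbers stand for an effect only at larger amounts of compound and lower numbers for an effect already at smaller amounts. There compound 1 gives 2.9 ug/mL. Compound 2 and compound 3 share the same core but carry other aromatic groups on the chain, and for neither was a result reported, so compound 1 stands alone as the reference point, with nothing measured to compare it against.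

Compound 4, `COC1=C(C)C(=O)/C(=C(O)/C=C/c2ccco2)C(=O)C1(C)C`, has not yet been tested. Its difference from compound 1 is furan-2-yl in place of 3-methoxyphenyl on a double-bonded chain carbon bound to a double-bonded chain carbon. Within the data shown here, no measured pair in this set shows what such a swap does, so the size of the step is open. A change of this kind, on the only attachment that varies across these compounds, is expected to move the value by a modest amount at most, in the direction of a weaker effect if anything. The estimated step from compound 1 to compound 4 in this assay is a 1.6-fold higher number from compound 1 to compound 4 (0.19 log units; within the scatter). Compound 4 is expected to give 4.5 ug/mL, within a range from 1.5 ug/mL to 14 ug/mL.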

Compound 4, concentration for half-maximal effect: 7.9 ug/mL
For compound 4 the middle estimate is 1.8-fold (0.24 log units) below the measured one, and the stated range covers the measured number.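

Among these compounds, this is the first measured step at this position: in this assay, furan-2-yl in place of 3-methoxyphenyl on a double-bonded chain carbon bound to a double-bonded chain carbon gives a 2.7-fold higher number from compound 1 to compound 4 (0.44 log units; beyond the scatter) and so shows that the group at this place can change the result. The swap alters the ring size, the number of heavy atoms and the ring's atoms all at once, and this single pair cannot separate those changes. No supporting evidence bears on why the number rises.

Compounds 2 and 3 have no numbers, so steps involving them cannot be read. Also open, from the compounds shown here alone, is how a pyridine ring, or a phenyl ring carrying an amine or a carboxylic acid, would read at this place in this assay on the shared core.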